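A few compounds are considered here, and "the series" means these few. Any claim that something is new, unique, unknown or untested is made for them only; others in the source may bear on it.

Compound 1 `COc1cc(C2=NN(C(C)=O)C(c3ccccc3C(F)(F)F)O2)cc(OC)c1OC` carries a 2-(trifluoromethyl)phenyl group on the saturated ring carbon of its five-membered ring. In a functional assay on BGC-823 cells (Homo sapiens) for antiproliferative activity, read by MTT assay, tested at 5 uM (on this read-out higher numbers stand for a stronger effect at the one concentration tested and lower numbers for a weaker effect), compound 1 gives 34.8%, the highest of the three numbers recorded. Compound 2 `COc1cc(C(=O)N/N=C/c2cccc(C(F)(F)F)c2)cc(OC)c1OC`, an open-chain relative, gives 33.8% in this assay, a number that sits within the scatter of the value for compound 1, so the two cannot be told apart. Compound 3 `COc1cc(C2=NN(C(C)=O)C(c3cc(OC)c(OC)c(OC)c3)O2)cc(OC)c1OC`, which bears a second trimethoxyphenyl group on the saturated ring carbon, gives -1.4%, far below compound 1 and beyond the scatter.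

Compound 4 `COc1cc(C2=NN(C(C)=O)C(c3ccc(Cl)c([N+](=O)[O-])c3)O2)cc(OC)c1OC` differs from compound 1 in one place: 4-chloro-3-nitrophenyl in place of 2-(trifluoromethyl)phenyl on a saturated ring carbon. Going by the values given here, no measured pair shows this exact exchange, so the expectation rests on the three numbers above. Compound 3 shows that a very different aryl group on this carbon can remove the effect, whereas compound 1 and compound 2 show that a trifluoromethyl-bearing ring keeps it. A 4-chloro-3-nitrophenyl group is expected to behave more like the ring of compound 1 than the ring of compound 3, so the expected step from compound 1 to compound 4 in this assay is a number 4.8 percentage points lower from compound 1 to compound 4 (within the scatter), within the scatter. Compound 4 is therefore estimated to give 30% in this assay, between 10% and 50%.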

Compound 4, a percentage reported as inhibition, at one concentration (the size of the read-out at that concentration, not a potency): 0%
For compound 4 the middle estimate is 30 percentage points above the measured one, outside the stated range (below it).
By their numbers in this assay, from the lowest: compounds 3 and 4 (each within the scatter of the next); then compounds 2 and 1 (each within the scatter of the next).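

The exchange of 2-(trifluoromethyl)phenyl for 4-chloro-3-nitrophenyl on the saturated ring carbon gives a number 34.8 percentage points lower from compound 1 to compound 4 (beyond the scatter) in this assay, so this position responds strongly to a swap between two substituted phenyl rings of equal heavy-atom count, and the loss seen with compound 3 is not confined to its trimethoxyphenyl group. Compound 4 at 0% stands within the scatter of compound 3 at -1.4%, so among the three aryl groups shown on this carbon, two different ones leave these compounds indistinguishable in this assay, and only the 2-(trifluoromethyl)phenyl group of compound 1 goes against that outcome. Nothing given here accounts for the size of this step.

The compounds shown leave open whether the chloro or the nitro group alone would carry the same loss, since both change together in compound 4, and whether an unsubstituted phenyl ring on this carbon would stand nearer to compound 1 or to compound 4. They also leave open how a ring bearing an amine or a carboxylic acid would read at this position.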